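Permeability notes: benzothiazole to pyridine-fused bicyclic amine exchange

This account rests on a few compounds, and the source may have more. Where it says the series, first, only, none or still open, it means among the compounds named here.

Measured compounds:
- compound 1 `c1cnc2c(c1)CCC[C@@H]2N(CCCN1CCNCC1)Cc1nc2ccccc2s1`: "not determined" (no result reported) in an ADME assay for permeability, using PAMPA, with a stated time of 4 h, at pH 7.4; on this read-out higher numbers stand for higher permeability and lower numbers for lower permeability
- compound 2 `c1ccc2c(c1)CN[C@@H](CN(CCCCN1CCNCC1)[C@H]1CCCc3cccnc31)C2`: 14 nm/s
- compound 3 `CN1CCN(CCCN(C[C@H]2Cc3ccccc3CN2C)[C@H]2CCCc3cccnc32)CC1`: 513 nm/s

Compound 1 has no number in this assay, so it cannot be placed on the permeability scale; it stands only as the starting structure. The two values in hand span the series: compound 2 gives 14 nm/s and compound 3 gives 513 nm/s, a gap well beyond the usual scatter, which shows how wide the read-out can swing within this set.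

Compound 4 `c1cnc2c(c1)CN[C@@H](CN(CCCN1CCNCC1)[C@H]1CCCc3cccnc31)C2` follows from compound 1 by one change (a group of 10 heavy atoms (8 carbon, 2 nitrogen; one six-membered non-aromatic ring with 1 hetero atom, one six-membered aromatic ring with 1 hetero atom) in place of a group of 9 heavy atoms (7 carbon, 1 nitrogen, 1 sulfur; one five-membered aromatic ring with 2 hetero atoms, one six-membered aromatic ring of carbon only), on a saturated chain carbon bound to an amine nitrogen). Within the data shown here, no measured step of this kind exists, so the direction and size of the change cannot be read from any pair here. With no reference value for compound 1, the estimate leans on the two measured values only, and the low value of compound 2 in this assay is taken as the more likely neighbourhood.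

Compound 4 is expected to show 12 nm/s in this assay, with a range from 3 nm/s to 45 nm/s.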

Compound 4, apparent permeability: 9 nm/s
For compound 4 the middle estimate is 1.3-fold (0.12 log units) above the measured one; low and high end bracket the measured number.
By their numbers in this assay, from the lowest: compounds 4 and 2 (each within the scatter of the next); then compound 3.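

Among these compounds, no step from compound 1 to compound 4 can be read in this assay, as compound 1 carries no number there. Going by these compounds, the effect of exchanging 1,3-benzothiazol-2-yl alone on permeability remains open. No supporting evidence bears on this result.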